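Swapping the difluorophenyl for a chloro-nitrophenyl

The compounds below may be only part of what the source reports. "The series", "measured", "known", "first", "only" and "open" are said of these compounds alone.

Compound 3 `Cc1ccc(N(C(=O)c2ccc(F)cc2F)C(=S)OCCN2C(=O)c3ccccc3C2=O)cc1` holds the lowest of the three numbers in an ADME assay on MT4 cells (Homo sapiens) for cytotoxicity, read by MTT assay; on this read-out lower numbers stand for higher toxicity in this test and higher numbers for lower toxicity in this test: it gives 20000 nM, while compound 1 `O=C1c2ccccc2C(=O)N1CCOC(=S)N(C(=O)c1ccc(F)cc1F)c1ccc(Cl)cc1` gives 52000 nM and compound 2 `O=C1c2ccccc2C(=O)N1CCOC(=S)N(C(=O)c1ccc(F)c(F)c1)c1ccc(Cl)cc1` gives 52000 nM; the step of a 2.6-fold lower number from compound 1 to compound 3 (0.41 log units; beyond the scatter) sets compound 3 apart. Compound 4 `Cc1ccc(N(C(=O)c2ccc(Cl)c([N+](=O)[O-])c2)C(=S)OCCN2C(=O)c3ccccc3C2=O)cc1` differs from compound 3 in one place: 4-chloro-3-nitrophenyl in place of 2,4-difluorophenyl on a carbonyl carbon. Among the measured compounds shown here, only one measured step touches this same ring, no change at the digits printed from compound 1 to compound 2 (within the scatter), where moving the fluorines left the number unchanged. For the measured compounds named here, no measured step brings a chloro or a nitro group onto this ring, so the expected step of a 1.1-fold higher number from compound 3 to compound 4 (0.04 log units; within the scatter) is small, likely none beyond the scatter. Compound 4 is therefore estimated at 22000 nM in this assay, with a range from 8000 nM to 60000 nM.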

Compound 4, half-maximal cytotoxic concentration: 47000 nM
Beside the measured number, compound 4's estimate is 2.1-fold (0.33 log units) below it; measured number inside the range.
By their numbers in this assay, from the lowest: compound 3; then compounds 4, 1 and 2 (each within the scatter of the next).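

Moving the fluorines around this ring had left the number unchanged, but replacing the whole 2,4-difluorophenyl on this carbonyl carbon with 4-chloro-3-nitrophenyl gives a 2.4-fold higher number from compound 3 to compound 4 (0.37 log units; beyond the scatter) in this assay. The group at this position can therefore shift the number modestly, here towards lower toxicity in this test. Nothing available explains this step.

The chloro and nitro groups enter together, and the compounds shown do not separate their shares in the step. From the compounds shown here alone, it also remains open how this ring would read with an amine or a carboxylic acid in their place.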